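A few compounds are considered here, and "the series" means these few. Any claim that something is new, unique, unknown or untested is made for them only; others in the source may bear on it.

Measured compounds:
Compound 1, `O=C(Nc1cccc(-n2cc(-c3ccncc3)c(-c3ccc(Cl)c(O)c3)n2)c1)Nc1cccc(C(F)(F)F)c1`, gives 29000 nM in a functional assay on NCI-H460 cells (Homo sapiens) for inhibition, read by sulforhodamine B assay, with a stated time of 48 h; a lower number here means a stronger inhibitor of growth, a higher number a weaker inhibitor of growth.
Compound 2, `O=C(Nc1cccc(-n2cc(-c3ccncc3)c(-c3ccc(Cl)c(O)c3)n2)c1)Nc1ccc(Cl)c(Cl)c1`, gives 3570 nM in this assay.
Compound 3, `COc1cc(-c2nn(-c3cccc(NC(=O)c4ccc(Cl)c(C(F)(F)F)c4)c3)cc2-c2ccncc2)ccc1Cl`, gives only a limit of the assay, > 32500 nM, in this assay.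

Compound 1 thus stands at the highest of the two plain numbers, the weaker inhibitor of growth of the pair, with compound 2 as its nearest neighbour. The third value, for compound 3, is a limit and not a number, as described by the limit of > 32500 nM in this assay, at which 1 of the 3 values shown sits; it cannot be ranked against the others.

The unmeasured compound 4, `O=C(Nc1cccc(-n2cc(-c3ccncc3)c(-c3ccc(Cl)c(O)c3)n2)c1)Nc1cc(C(F)(F)F)cc(C(F)(F)F)c1`, differs from compound 1 in one place: trifluoromethyl in place of hydrogen on an aromatic carbon. For the measured compounds named here, the only measured step touching the same part of the shared core is the one where the phenyl on the urea nitrogen was changed, an 8.1-fold lower number from compound 1 to compound 2 (0.91 log units; beyond the scatter). That step shows that swapping substituents on this ring can move the number modestly, but it does not say which way a second trifluoromethyl will push. A modest change in either direction, or none beyond the scatter, is therefore plausible in this assay.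

Compound 4 is expected to give about 18000 nM, within 5000 nM to 40000 nM, which corresponds to an expected 1.6-fold lower number from compound 1 to compound 4 (0.21 log units; within the scatter).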

Compound 4, concentration for total growth inhibition: 1480 nM
For compound 4 the middle estimate is 12-fold (1.09 log units) above the measured one; the whole stated range lies above it.
By their numbers in this assay, from the lowest: compound 4; then compound 2; then compound 1. At a limit, above all of these: compound 3.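

Placing a trifluoromethyl group on the aromatic carbon meta to the existing trifluoromethyl group gives a 20-fold lower number from compound 1 to compound 4 (1.29 log units; beyond the scatter) in this assay. The earlier step, an 8.1-fold lower number from compound 1 to compound 2 (0.91 log units; beyond the scatter), exchanged one substitution pattern on this ring for another, so it could not show what a single added group does while the original trifluoromethyl stays in place. The new step isolates that change: hydrogen leaves, trifluoromethyl enters, nothing else differs, and the result is a much stronger inhibitor of growth, so this one aromatic carbon strongly affects the number in this series.

For the compounds shown here, nothing among the values shown explains why this single added group moves the number so far. As far as these compounds go, it also remains open whether this effect is particular to trifluoromethyl or would appear with other groups on the same carbon, such as a nitrile, an amine or a carboxylic acid, and whether compounds with those groups would keep, lose or exceed the growth inhibition seen for compound 4.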